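The source may hold more compounds than are shown below. What is called first, only, known or untested is meant among the compounds shown, and "the series" means these compounds.

In a functional assay on A549 cells (Homo sapiens) for inhibition, read by MTT assay, with a stated time of 72 h (on this read-out higher numbers stand for weaker inhibition and lower numbers for stronger inhibition), compound 1 (`Cc1ccccc1-c1cc(C(=O)N2CCC3(CC2)CC(=O)c2nn(C(C)(C)C)cc2O3)c2ccccc2n1`) gives 1880 nM and compound 2 (`COc1ccc(-c2cc(C(=O)N3CCC4(CC3)CC(=O)c3nn(C(C)(C)C)cc3O4)c3ccccc3n2)cc1`) gives 3740 nM within the scatter of it. Compound 3 (`COc1ccc(-c2cc(C(=O)N3CCC4(CC3)CC(=O)c3nn(C(C)(C)C)cc3O4)c3ccccc3n2)cc1OC`) differs from compound 2 by methoxy in place of hydrogen on an aromatic carbon in turning 4-methoxyphenyl into 3,4-dimethoxyphenyl, with methoxy in place of hydrogen on an aromatic carbon. For the measured compounds named here, the only measured step on that aromatic group is a 2.0-fold higher number from compound 1 to compound 2 (0.30 log units; within the scatter) and it gives no ground for a large move. No change beyond the scatter is therefore expected in this assay and no direction can be favoured. The estimated step is a 1.2-fold lower number from compound 2 to compound 3 (0.07 log units; within the scatter) and stays small. Compound 3 is estimated at 3200 nM (from 1300 nM to 8000 nM).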

Compound 3, half-maximal inhibitory concentration: 2030 nM
Estimate against measurement, compound 3: 1.6-fold (0.20 log units) above; the measured number falls inside the stated range.
By their numbers in this assay, from the lowest: compounds 1, 3 and 2 (each within the scatter of the next).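

In this assay, methoxy in place of hydrogen, ortho to a methoxy group, leaves the number within the scatter (a 1.8-fold lower number from compound 2 to compound 3 (0.27 log units; within the scatter)). Exchanging the whole aromatic group also stays within the scatter (a 1.1-fold higher number from compound 1 to compound 3 (0.03 log units; within the scatter)), so 3,4-dimethoxyphenyl and 2-methylphenyl cannot be told apart on this read-out. No measured evidence bears on these steps.

From the compounds shown here alone, whether any group at this position moves the number beyond the scatter remains open. An amine or a carboxylic acid on this aromatic ring would test that, in place of methoxy.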